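Working notes: sulfonamide nitrogen substituents, compounds 1 to 3

The source may hold more compounds than are shown below. What is called first, only, known or untested is meant among the compounds shown, and "the series" means these compounds.

Measured so far:
- compound 1, `CCCCNS(=O)(=O)c1ccc(Nc2ncc3c(n2)N(C2CCCC2)[C@H](CC)C(=O)N3C)cc1`: 19.9 nM in an assay for inhibition of serine/threonine-protein kinase PLK2 (Homo sapiens), read by FRET and Z'-LYTE, with a stated time of 1 h; on this read-out lower numbers stand for stronger inhibition and higher numbers for weaker inhibition
- compound 2, `CC[C@@H]1C(=O)N(C)c2cnc(Nc3ccc(S(=O)(=O)NC4CCCC4)cc3)nc2N1C1CCCC1`: 23.9 nM in this assay

Among the compounds with values here, the only measured step, a 1.2-fold higher number from compound 1 to compound 2 (0.08 log units; within the scatter), lies within the scatter, so the two measured compounds are not separated by this assay; compound 2 stands beside compound 1 with no meaningful gap between them.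

Compound 3, `CC[C@@H]1C(=O)N(C)c2cnc(Nc3ccc(S(=O)(=O)NCCO)cc3)nc2N1C1CCCC1`, differs from compound 2 in one place: 2-hydroxyethyl in place of cyclopentyl on a sulfonamide nitrogen.

The step that bears on this is a 1.2-fold higher number from compound 1 to compound 2 (0.08 log units; within the scatter), which exchanged one hydrocarbon group for another on the same sulfonamide nitrogen without moving the number beyond the scatter. Within the data shown here, that is the sole precedent; no measured compound carries a hydrogen-bond donor or acceptor at this position, so the effect of the hydroxyl is not covered by the data. Among the measured compounds shown here, on the one relevant step, the expectation for compound 3 is a change of about a 1.3-fold higher number from compound 2 to compound 3 (0.10 log units; within the scatter), that is, none beyond the scatter, with the range widened for the untested oxygen. The estimated value for compound 3 in this assay is 30 nM, between 10 nM and 90 nM.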

Compound 3, half-maximal inhibitory concentration: 7.86 nM
Compound 3: middle estimate off by 3.8-fold (0.58 log units), on the high side, outside the stated range (below it).
By their numbers in this assay, from the lowest: compound 3; then compounds 1 and 2 (each within the scatter of the next).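

In this assay, this position on the sulfonamide nitrogen turns out not to be indifferent to its substituent: 2-hydroxyethyl in place of cyclopentyl gives a 3.0-fold lower number from compound 2 to compound 3 (0.48 log units; beyond the scatter), and hydroxy in place of ethyl on the saturated chain, two bonds along from the sulfonamide nitrogen, gives a 2.5-fold lower number from compound 1 to compound 3 (0.40 log units; beyond the scatter). Both steps lie beyond the scatter, though modest in size, so compound 3, the only one of the three with a hydrogen-bond donor and acceptor in this substituent, separates from the ring-bearing compound 2 and the open-chain compound 1, which this assay does not separate from each other. Nothing measured here explains why the number falls with this change.

Going by these compounds, the comparison with compound 2 changes the ring, the heavy-atom count and the oxygen together, and the comparison with compound 1 also changes chain length along with the hydroxyl, so it remains open whether the oxygen or the shorter chain matters; an ethyl or a 2-methoxyethyl group on the same nitrogen would separate these. On these data alone, how a 2-aminoethyl group or a carboxylic acid at the end of the chain would compare with compound 3 also remains open.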